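A few compounds are considered here, and "the series" means these few. Any claim that something is new, unique, unknown or untested is made for them only; others in the source may bear on it.

Among the compounds with values here, in a functional assay on HT-29 cells (Homo sapiens) for inhibition, read by sulforhodamine B assay, with a stated time of 48 h (a higher number here means a weaker inhibitor of growth, a lower number a stronger inhibitor of growth), two compounds sharing one core have numbers so far. Compound 1 `CN1CCN(CCCOc2cccc3nc(Nc4ccc(Cl)c(F)c4)ccc23)CC1` gives 1410 nM, and compound 2 `CN1CCN(CCCOc2cccc3nc(Nc4ccc(F)c(F)c4)ccc23)CC1` gives 620 nM, the lower of the two. Within the data shown here, the one measured step, a 2.3-fold lower number from compound 1 to compound 2 (0.36 log units; beyond the scatter), is modest but beyond the scatter, and it comes with fluoro in place of chloro on an aromatic carbon.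

Compound 3 `CN1CCN(CCCOc2cccc3nc(Nc4cccc(Cl)c4)ccc23)CC1` has not yet been measured. It carries 3-chlorophenyl in place of 3,4-difluorophenyl on a nitrogen on an aromatic ring. Among the measured compounds shown here, only the step between the two measured compounds bears on this change, and it matches the change only in part. For the measured compounds named here, no measured step isolates the loss of a fluoro, so the expectation remains loose. Read in reverse, a 2.3-fold lower number from compound 1 to compound 2 (0.36 log units; beyond the scatter) suggests that a chloro in compound 3 would go with a higher number, by a modest amount. The expected step is a 1.9-fold higher number from compound 2 to compound 3 (0.29 log units; within the scatter), with the number rising. For compound 3 the estimated value is 1200 nM, with an expected range from 450 nM to 3000 nM.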

Compound 3, concentration for 50% growth inhibition: 1500 nM
Compound 3: middle estimate off by 1.3-fold (0.10 log units), on the low side; the range from low to high includes it.
By their numbers in this assay, from the lowest: compound 2; then compounds 1 and 3 (each within the scatter of the next).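

In this assay, the change at this nitrogen on an aromatic ring gives a 2.4-fold higher number from compound 2 to compound 3 (0.38 log units; beyond the scatter), so replacing 3,4-difluorophenyl with 3-chlorophenyl has a modest effect beyond the scatter, about as large as the earlier step from chloro to fluoro. The new comparison among the chlorine-bearing groups gives a 1.1-fold higher number from compound 1 to compound 3 (0.03 log units; within the scatter), which lies within the scatter, so the 3-chlorophenyl and 4-chloro-3-fluorophenyl groups cannot be told apart in this assay. Compound 2, the only one of the three without chlorine on this ring, now has the lowest number, with steps beyond the scatter to both compound 1 and compound 3, though no information on why this is so accompanies these results.

The compounds shown leave open whether chlorine itself marks the difference or whether the 3,4-difluorophenyl pattern is what sets compound 2 apart. A 3-fluorophenyl or 3,4-dichlorophenyl group on the same nitrogen would separate these two readings, and an unsubstituted phenyl group would show what any halogen on this ring contributes.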